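This account rests on a few compounds, and the source may have more. Where it says the series, first, only, none or still open, it means among the compounds named here.

Three compounds have values so far in an ADME assay on PBMC cells (Homo sapiens) for cytotoxicity, with a stated time of 5 days (on this read-out lower numbers stand for stronger inhibition and higher numbers for weaker inhibition), so far:
- compound 1 `C=CCNc1ncnc2c1ncn2[C@H]1C[C@H](N=[N+]=[N-])[C@@H](CO)O1` gives 51100 nM 
- compound 2 `C=CCNc1nc(N)nc2c1ncn2[C@H]1C[C@H](N=[N+]=[N-])[C@@H](CO)O1` gives > 100000 nM (a limit of the assay, not a number)
- compound 3 `[N-]=[N+]=N[C@H]1C[C@H](n2cnc3c(Cl)nc(F)nc32)O[C@@H]1CO` gives 7200 nM 

Compound 2 has no number of its own and stands at the limit of > 100000 nM in this assay, at which 1 of the 3 values shown sits, in this small set. Compound 4 `[N-]=[N+]=N[C@H]1C[C@H](n2cnc3c(NCCO)nc(N)nc32)O[C@@H]1CO` differs from compound 2 by hydroxymethyl in place of vinyl on a saturated chain carbon bound to a nitrogen on an aromatic ring and so reads as allyl to 2-hydroxyethyl. Going by the values given here, only one measured step is available, an at least 1.9-fold higher number from compound 1 to compound 2 (0.29 log units; that floor lies within the scatter) and it is amino in place of hydrogen on an aromatic carbon, a different change that compound 4 retains. Among the compounds with values here, no measured step covers the exchange at the chain. The sole reference is the limit of compound 2 at > 100000 nM so no change beyond the scatter is expected in this assay here. The expected outcome is a number no higher from compound 2 to compound 4 (the limit leaves the size open) as an estimate only. Compound 4 is estimated at 100000 nM (expected range 40000 nM to 200000 nM) and the assay may well report only a limit.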

Compound 4, half-maximal inhibitory concentration: > 100000 nM
Compound 4: a limit, no number; the forecaster's own chance of this, stated with the estimate: 60%; the middle value lies on the limit itself.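

In this assay, compound 2 and compound 4 both stand at a limit and not at a number, and no step can be read between them. The compounds shown leave open how exchanging allyl for 2-hydroxyethyl affects this read-out, and whether it affects it at all.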